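The source may hold more compounds than are shown below. What is called first, only, known or untested is meant among the compounds shown, and "the series" means these compounds.

Compound 1 `CCCOc1nc(N)nc2c1ncn2/C=C1/CC1(CO)CO` carries a propoxy group on the shared core. In an ADME assay on MOLT-3 cells (Homo sapiens) for cytotoxicity, with a stated time of 7 days (on this read-out higher numbers stand for lower toxicity in this test and lower numbers for higher toxicity in this test), compound 1 gives > 20000 nM, which is a limit of the assay rather than a number. Compound 3 `CCCCCCOc1nc(N)nc2c1ncn2/C=C1/CC1(CO)CO` gives > 20000 nM in this assay, again a limit. The step that the two limits leave unreadable from compound 1 to compound 3 is hence unreadable in size. Compound 2 `Nc1nc(N2CCCC2)c2ncn(/C=C3/CC3(CO)CO)c2n1` has "not determined" (no result reported) in this assay. Compound 4 `Nc1nc(SCc2ccccc2)c2ncn(/C=C3/CC3(CO)CO)c2n1` differs from compound 1 by benzylsulfanyl in place of propoxy on an aromatic carbon. Among the compounds with values here, the only measured step bearing on this change is the one from the two limits, and it gives no size; what is seen is the limit of > 20000 nM in this assay, at which 2 of the 3 values shown sit. No step beyond the scatter is expected, and compound 4 is estimated at 20000 nM in this assay, between 7000 nM and 60000 nM. The expected step is a number no higher from compound 1 to compound 4 (the limit leaves the size open).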

Compound 4, half-maximal cytotoxic concentration: > 20000 nM
Compound 4 was reported as a limit (the forecaster's own chance of this, stated with the estimate: 70%); the middle value lies on the limit itself.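

In this assay no step among compound 1, compound 3 and compound 4 can be read, as all three are reported only as limits: the limit of > 20000 nM in this assay, at which 3 of the 4 values shown sit.
Going by these compounds, whether propoxy, hexyloxy and benzylsulfanyl differ at all in this read-out stays open.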